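The compounds below may be only part of what the source reports. "The series", "measured", "known", "first", "only" and "open" are said of these compounds alone.

In a toxicity assay on HEK-293T cells (Homo sapiens) for cytotoxicity, read by MTT assay, with a stated time of 72 h (on this read-out higher numbers stand for weaker inhibition and lower numbers for stronger inhibition), compound 2 `CC1(C)O[C@@H](CO)[C@H](Cn2cc(Cn3c4c(c5ccccc53)C(=O)c3c[n+]([O-])c5ccccc5c3C4=O)nn2)O1` gives 120 nM and holds the lower of the two numbers, while compound 1 `O=C1c2c[n+]([O-])c3ccccc3c2C(=O)c2c1c1ccccc1n2Cc1cn([C@H]2O[C@H](CO)[C@@H](O)[C@H]2O)nn1` gives 1370 nM on the same read-out. Compound 3 `O=C1c2c[n+]([O-])c3ccccc3c2C(=O)c2c1c1ccccc1n2Cc1cn([C@H]2C[C@H](O)[C@@H](CO)O2)nn1` carries 4-hydroxy-5-(hydroxymethyl)oxolan-2-yl in place of (5-(hydroxymethyl)-2,2-dimethyl-1,3-dioxolan-4-yl)methyl on an aromatic nitrogen and so returns to an oxolan-2-yl group, as in compound 1. For the measured compounds named here, the only measured step bearing on this is the large 11-fold lower number from compound 1 to compound 2 (1.06 log units; beyond the scatter) in the opposite exchange of groups. Most of that step is expected to be undone in this assay, giving the expected 5.8-fold higher number from compound 2 to compound 3 (0.77 log units; beyond the scatter) as a rise. For compound 3 the estimate is 700 nM with a range from 220 nM to 1800 nM around it.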

Compound 3, half-maximal inhibitory concentration: 3600 nM
Estimate against measurement, compound 3: 5.1-fold (0.71 log units) below, and the stated range ends below it.
By their numbers in this assay, from the lowest: compound 2; then compound 1; then compound 3.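

In this assay, going back to an oxolan-2-yl group does more than cancel the earlier drop: a 30-fold higher number from compound 2 to compound 3 (1.48 log units; beyond the scatter), which leaves compound 3 with the highest number of the three. The position also separates the two oxolan-2-yl groups, with a 2.6-fold higher number from compound 1 to compound 3 (0.42 log units; beyond the scatter), so the number here depends on more than the ring type. No evidence on why these numbers shift is available. Open, as far as these compounds go, is whether an open chain such as 2,3-dihydroxypropyl, or an oxolan-2-yl group carrying an amine, would sit nearer compound 2 or compound 3.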